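The source may report more compounds than this note shows. Statements on the series, on what has been measured and on what is new or still open speak of the compounds shown alone.

Three large ring-shaped molecules have so far been tested in a functional assay on cell membranes from cells (Erythrocyte, Homo sapiens), read by spectrophotometry, with a stated time of 30 min, tested at 50 ug/mL; a higher number here means a stronger effect of the compound at the concentration tested, a lower number a weaker effect. Compound 1 `O=C1NCc2ccc(cc2)-c2cccc(c2)-c2ccc(cc2)CNC(=O)c2cccc(c2)OCc2cc(cc([N+](=O)[O-])c2)COc2cccc1c2` gives 76%. Compound 2 `O=C1COc2ccccc2-c2ccccc2OCC(=O)NCc2ccc(cc2)-c2cccc(c2)-c2ccc(cc2)CN1` gives 85.7%, and compound 3 `O=C1NCc2ccc(cc2)-c2cccc(c2)-c2ccc(cc2)CNC(=O)c2cccc(c2)OCc2ccc(cc2)-c2cccc(c2)-c2ccc(cc2)COc2cccc1c2` gives 71.7%; both of these values lie within the usual scatter of the value of compound 1, so the three compounds cannot be told apart on these numbers. Compound 4 `O=C1NCc2ccc(cc2)-c2cccc(c2)-c2ccc(cc2)CNC(=O)c2cccc(c2)OCc2cccc(c2)COc2cccc1c2` has not yet been measured in this assay. It differs from compound 1 in one place: hydrogen in place of nitro on an aromatic carbon. Going by the values given here, no measured pair shows a change of this kind, so the expectation rests only on how close the three known values sit to one another. The expected step is a number 2 percentage points lower from compound 1 to compound 4 (within the scatter), one that stays within the scatter. Compound 4 is therefore estimated to give 74%, with a range from 60% to 88%.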

Compound 4, a percentage reported as activity, at one concentration (the size of the read-out at that concentration, not a potency): 72.5%
For compound 4 the middle estimate is 1.5 percentage points above the measured one, within the range that was stated.
By their numbers in this assay, from the lowest: compounds 3, 4, 1 and 2 (each within the scatter of the next, the first and the last beyond it).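

Going by these compounds alone, this is the first pair of compounds that differ in only one place. In this assay, hydrogen in place of nitro on this aromatic carbon gives a number 3.5 percentage points lower from compound 1 to compound 4 (within the scatter), so at this position the nitro group is not needed for the read-out to stay at this level. No measurement shown here gives a reason for this result. From the compounds shown here alone, whether an amine or a carboxylic acid on the same carbon would read the same remains open. Going by these compounds, the read-out also comes from a single concentration, so any difference in potency between compound 1 and compound 4 stays unknown.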